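Compound 2 and Its Tetrahydroquinoline Analogue, Compound 4

The source may hold more compounds than are shown below. What is called first, only, known or untested is meant among the compounds shown, and "the series" means these compounds.

Three compounds built on a shared core were examined in an assay on isolated protein for inhibition of thyroid hormone receptor beta (Homo sapiens), read by fluorescence polarization; on this read-out lower numbers stand for stronger inhibition and higher numbers for weaker inhibition. Compound 1 `CN(CC(=O)N1CCN(c2ccccc2)CC1)C(=O)c1ccc(S(C)(=O)=O)c([N+](=O)[O-])c1` returned only a limit of the assay, > 60000 nM. Compound 3 `CC1CCN(C(=O)CCCNC(=O)c2ccc(S(C)(=O)=O)c([N+](=O)[O-])c2)CC1` also returned only a limit, > 60000 nM. Compound 2 `CS(=O)(=O)c1ccc(C(=O)NCCC(=O)N2CCc3ccccc32)cc1[N+](=O)[O-]` likewise gave a limit rather than a number, > 60000 nM. Compound 2 thus stands exactly where every other value shown stands, because of the limit of > 60000 nM in this assay, at which 3 of the 3 values shown sit. Among the measured compounds shown here, no two measured compounds differ from each other in a single place, so no measured step is available to read.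

Compound 4 `CS(=O)(=O)c1ccc(C(=O)NCCC(=O)N2CCCc3ccccc32)cc1[N+](=O)[O-]` has not yet been measured in this assay. It differs from compound 2 in one place: 1,2,3,4-tetrahydroquinolin-1-yl in place of 2,3-dihydro-1H-indol-1-yl on a carbonyl carbon. With all three measured values sitting at the same limit, nothing in the data points to a change in either direction for compound 4, and no step beyond the usual scatter is anticipated.

Compound 4 is therefore expected to give roughly 100000 nM in this assay, within an expected range from 30000 nM to 400000 nM. The step this estimate implies is a step that the limit leaves unreadable from compound 2 to compound 4, expected to lie within the scatter of repeated measurements.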

Compound 4, half-maximal inhibitory concentration: > 60000 nM
Compound 4 ended at the assay's limit; the forecaster's own chance of this, stated with the estimate: 85%; the middle value lies beyond the limit too.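

No step from compound 2 to compound 4 can be read, because both compounds end at a limit and not at a number: the limit of > 60000 nM in this assay, at which 4 of the 4 values shown sit.

The compounds shown leave open whether 1,2,3,4-tetrahydroquinolin-1-yl in place of 2,3-dihydro-1H-indol-1-yl changes inhibition in this assay at all, and what on the shared core would give a measurable value.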